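Ethoxycarbonyl Enters the Core of Compound 1

A few compounds are considered here, and "the series" means these few. Any claim that something is new, unique, unknown or untested is made for them only; others in the source may bear on it.

Of the two numbers shown in a functional assay on the whole organism (strain Wistar) for inhibition, with Rattus norvegicus as the target, read by paw edema, with stated times of 3 h and 1 h, at a dose of 6 mg/kg by the oral route (on this read-out higher numbers stand for more inhibition at the one dose given (going by the name of the read-out) and lower numbers for less inhibition), compound 1 `O=C(CO[N+](=O)[O-])NNC(=O)c1ccc(-n2[nH]c(=O)cc2-c2ccc([N+](=O)[O-])cc2)cc1` gives 24%, and compound 2 `O=C(CO[N+](=O)[O-])NNC(=O)c1ccc(-n2[nH]c(=O)cc2-c2ccccc2O)cc1` gives 16.4%, so the step of a number 7.6 percentage points lower from compound 1 to compound 2 (within the scatter) places the two side by side. Compound 3 `CCOC(=O)c1c(-c2ccc([N+](=O)[O-])cc2)n(-c2ccc(C(=O)NNC(=O)CO[N+](=O)[O-])cc2)[nH]c1=O` differs from compound 1 by ethoxycarbonyl in place of hydrogen on an aromatic carbon. For the measured compounds named here, the one measured step touched the 4-nitrophenyl group, not this position, and stayed within the scatter, so nothing measured bears directly on the new change. Compound 3 is therefore expected to show no change at the digits printed from compound 1 to compound 3 (within the scatter), no step beyond the scatter. The estimate for compound 3 is 24%, from 10% to 38%.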

Compound 3, a percentage reported as inhibition, in the whole organism at one dose (the size of the read-out at that dose, not a potency): 22.2%
For compound 3 the middle estimate is 1.8 percentage points above the measured one; low and high end bracket the measured number.
By their numbers in this assay, from the lowest: compounds 2, 3 and 1 (each within the scatter of the next).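

Placing ethoxycarbonyl on this aromatic carbon of the five-membered ring, where hydrogen stood, gives a number 1.8 percentage points lower from compound 1 to compound 3 (within the scatter) in this assay. For the compounds shown here, this is the first measured change at this position, and it shows that a group of this size here, with its 5 heavy atoms, keeps the read-out within the scatter of compound 1. No measurement at hand speaks to the reason for this result.

On these data alone, whether an amine, a carboxylic acid or a longer ester chain on this carbon would read the same stays open. So does whether ethoxycarbonyl would do the same alongside the 2-hydroxyphenyl group of compound 2.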